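This account rests on a few compounds, and the source may have more. Where it says the series, first, only, none or still open, it means among the compounds named here.

Of the compounds shown here, three sharing one core have been measured in an ADME assay on PANC-1 cells (Homo sapiens) for cytotoxicity, read by sulforhodamine B assay, with a stated time of 48 h, tested at 10 uM; a lower number here means less inhibition, a higher number more inhibition at the concentration tested (going by the name of the read-out). Compound 1, `CCCCCCCc1cn(C(c2ccccc2)c2cc3cc(Br)ccc3nc2OC)nn1`, gives 16.6%. Compound 2, `COc1nc2ccc(Br)cc2cc1C(c1ccccc1)n1cc(-c2cccc(F)c2)nn1`, gives 15.5%. Compound 3, `COc1nc2ccc(Br)cc2cc1C(c1ccccc1)n1cc(CCO)nn1`, gives 19.8%. Compound 3 carries the highest of the three numbers, yet its separations from the other two, a number 3.2 percentage points higher from compound 1 to compound 3 (within the scatter) and a number 4.3 percentage points higher from compound 2 to compound 3 (within the scatter), both lie within the scatter, so the three values cannot be told apart. The step between the first two, a number 1.1 percentage points lower from compound 1 to compound 2 (within the scatter), is likewise within the scatter.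

Compound 4, `COc1nc2ccc(Br)cc2cc1C(c1ccccc1)n1cc(-c2ccccc2)nn1`, has not yet been measured. phenyl in place of 2-hydroxyethyl on an aromatic carbon The step most directly bearing on this change is a number 4.3 percentage points higher from compound 2 to compound 3 (within the scatter), which runs the opposite way, swapping an aromatic group for the 2-hydroxyethyl group, and stayed within the scatter. The step of a number 1.1 percentage points lower from compound 1 to compound 2 (within the scatter), where the 3-fluorophenyl group arrived, also stayed within the scatter. Nothing among these three compounds points to a movement beyond the scatter in this assay for compound 4. The step from compound 3 is expected to be a number 3.8 percentage points lower from compound 3 to compound 4 (within the scatter). Compound 4 is therefore estimated at 16%, in a range of 7% to 26%.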

Compound 4, a percentage reported as inhibition, at one concentration (the size of the read-out at that concentration, not a potency): 30.1%
Compound 4: the middle estimate sits 14.1 percentage points below what was measured; the measured number lies above the stated range.
By their numbers in this assay, from the lowest: compounds 2, 1 and 3 (each within the scatter of the next); then compound 4.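

In this assay, among these compounds, the substituent on the five-membered aromatic ring with 3 nitrogen now makes a visible difference, which none of the earlier steps showed: phenyl in place of 2-hydroxyethyl gives one step beyond the scatter (a number 10.3 percentage points higher from compound 3 to compound 4 (beyond the scatter)), and phenyl in place of heptyl gives another (a number 13.5 percentage points higher from compound 1 to compound 4 (beyond the scatter)). The step from the 3-fluorophenyl group is the most informative, since losing only the fluoro gives the largest change of the set (a number 14.6 percentage points higher from compound 2 to compound 4 (beyond the scatter)), so the higher number cannot be credited to any aromatic ring at this place, only to the plain phenyl as opposed to the 3-fluorophenyl of compound 2. Nothing available explains why one fluoro separates these two compounds.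

As far as these compounds go, it remains open whether a chloro or a methoxy on the phenyl ring would bring the number back down as the fluoro does, and whether a pyridine ring or a benzyl group would keep the higher number. From the compounds shown here alone, each number also comes from a single concentration, so the potency of compound 4 in this assay remains unknown.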